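The source may hold more compounds than are shown below. What is called first, only, known or untested is meant among the compounds shown, and "the series" means these compounds.

Compound 1 `Cc1cc(=O)[nH]c(=O)n1COC(CO)CO`: in a functional assay on HeLa cells (Homo sapiens) for inhibition, read by MTT assay, with a stated time of 72 h (a higher number here means a weaker inhibitor, a lower number a stronger inhibitor), compound 1 gives > 100000 nM, a limit of the assay rather than a number.
Compound 2 `O=c1ccn(COC(CO)CO)c(=O)[nH]1`: in this assay compound 2 gives > 100000 nM, likewise a limit.
Compound 3 `Cc1ccc(S(=O)(=O)Nc2ccn(C)c(=O)n2)cc1`: in this assay compound 3 gives > 100000 nM, again a limit.

Compound 2 thus stands only at a limit, as do the other two values shown, all sitting at the limit of > 100000 nM in this assay, at which 3 of the 3 values shown sit. Among the measured compounds shown here, the single step joining two measured compounds, a step that the two limits leave unreadable from compound 1 to compound 2, cannot be read from two limits. Compound 4 `O=c1[nH]c(=O)n(COC(CO)CO)cc1O` differs from compound 2 by hydroxy in place of hydrogen on an aromatic carbon. For the measured compounds named here, no measured step bears on this change with a readable size, so no direction can be drawn from the data. In this assay compound 4 is therefore expected to sit at the limit as well, estimated at 100000 nM with a range of 30000 nM to 300000 nM. The expected step of a number no higher from compound 2 to compound 4 (the limit leaves the size open) is estimated as none beyond the scatter.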

Compound 4, half-maximal inhibitory concentration: > 100000 nM
Compound 4: only a limit was reported; the forecaster's own chance of this, stated with the estimate: 85%; the middle value lies on the limit itself.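

No new step can be read: compound 2 and compound 4 each stand only at a limit in this assay. The compounds shown leave open whether hydroxy in place of hydrogen on an aromatic carbon changes inhibition at all.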